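A ring swap on the lowest of three compounds

The source may hold more compounds than are shown below. What is called first, only, known or untested is meant among the compounds shown, and "the series" means these compounds.

In a physicochemical assay for lipophilicity, read by HPLC, at pH 7.5 (on this read-out lower numbers stand for lower lipophilicity and higher numbers for higher lipophilicity), so far, compound 1 `CCOc1ccccc1-c1ccc(-c2nc3cncc(Cl)c3c(N[C@H](CC)C(N)=O)c2C#N)cc1` gives 3.7 and compound 3 `CCOc1ccccc1-c1ccc(-c2nc3cnccc3c(C[C@H](C)C(N)=O)c2C#N)cc1` gives 3 while compound 2 `CC[C@@H](Nc1c(C#N)c(-c2ccc(-c3ccncc3C)cc2)nc2cnccc12)C(N)=O` gives 2 and so stands lowest of the three. Its gaps to both of the others lie beyond the usual scatter of repeated measurements.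

Compound 4 `CC[C@@H](Nc1c(C#N)c(-c2ccc(-c3ccccc3COC)cc2)nc2cnccc12)C(N)=O` has not been measured yet. It differs from compound 2 in one place 2-(methoxymethyl)phenyl in place of 3-methylpyridin-4-yl on an aromatic carbon with 2-(methoxymethyl)phenyl in place of 3-methylpyridin-4-yl on an aromatic carbon of a six-membered aromatic ring of carbon only.

Going by the values given here, no two measured compounds differ in just one place, so no direct step is available as a guide. The only hint is indirect. Compound 3 at 3 and compound 1 at 3.7 both end in a six-membered aromatic ring of carbon only, as compound 4 does, but they also differ from compound 2 elsewhere, which makes them a loose guide.

A rise is therefore expected in this assay and the estimated size is a number 0.80 log units higher from compound 2 to compound 4 (beyond the scatter) which would lie beyond the scatter. Compound 4 is expected at 2.8 with a likely range from 2.2 to 3.4 on this estimate.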

Compound 4, distribution coefficient: 2.6
Compound 4: the middle estimate sits 0.20 log units above what was measured; the measured number falls inside the stated range.
By their numbers in this assay, from the lowest: compound 2; then compound 4; then compound 3; then compound 1.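

Going by these compounds alone, this is the first direct comparison at this position. In this assay, putting 2-(methoxymethyl)phenyl in place of 3-methylpyridin-4-yl, with the rest of the molecule unchanged, gives a number 0.60 log units higher from compound 2 to compound 4 (beyond the scatter), so exchanging this end ring moves the read-out by a modest but real amount, even though the counts of hydrogen-bond donors and acceptors stay the same and neither group carries a net charge. No supporting measurement is available to explain the step, so it stands as an observation about this pair alone.

The swap removes the ring nitrogen and the methyl group and brings in a carbon-only ring with a methoxymethyl group, all in one move, so the compounds shown leave open how much of the step belongs to the ring and how much to the group on it. A plain phenyl ring or a 2-methylphenyl group at this position would help separate the two, and an amine in place of the methoxy end of the side chain remains an open question as well.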